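The source may hold more compounds than are shown below. What is called first, only, known or untested is meant among the compounds shown, and "the series" means these compounds.

Measured compounds in the series:

- compound 1, `O=C(NCCCOc1ccc2nc(O)ccc2c1)N(C1CCCCC1)[C@H]1CCCC[C@@H]1O`: 57%
- compound 2, `O=C(NCCCOc1ccc2nc(O)ccc2c1)N(C1CC1)[C@H]1CCCC[C@H]1O`: 100%
- compound 3, `CCCCO[C@H]1CCCC[C@@H]1N(C(=O)NCCCOc1ccc2nc(O)ccc2c1)C1CC1`: 33%

All three numbers come from a functional assay on the whole organism for inhibition, with Mus musculus as the target, at a dose of 30 mg/kg by the oral route; on this read-out lower numbers stand for less inhibition and higher numbers for more inhibition at the one dose given (going by the name of the read-out). Compound 3 stands lowest of the three; the nearest is compound 1, whose number sits above it beyond the scatter, and the furthest is compound 2, which gives the top reading of the set.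

The next compound, compound 4, is `O=C(NCCCOc1ccc2nc(O)ccc2c1)N(C1CC1)[C@H]1CCCC[C@@H]1O`. Set against compound 3 the change is hydrogen in place of butyl on an oxygen on a saturated carbon. Going by the values given here, the one measured step that bears on it is the same change run the other way: a number 67 percentage points lower from compound 2 to compound 3 (beyond the scatter). Among the compounds with values here, compound 4 undoes that change on the butoxy oxygen while keeping the cyclopropyl on the amide-type nitrogen, so a step of comparable size back upward is expected, with the note that only one such pair exists here and that compound 1 shows the hydroxy series does not always reach the top reading.

For compound 4 the expectation is therefore 85%, within 55% to 100%, which means an expected step of a number 52 percentage points higher from compound 3 to compound 4 (beyond the scatter).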

Compound 4, a percentage reported as inhibition, in the whole organism at one dose (the size of the read-out at that dose, not a potency): 100%
The estimate for compound 4 lay 15 percentage points below the measured number; low and high end bracket the measured number.
By their numbers in this assay, from the lowest: compound 3; then compound 1; then compounds 2 and 4 (each within the scatter of the next).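

In this assay, hydrogen in place of butyl on the oxygen gives a number 67 percentage points higher from compound 3 to compound 4 (beyond the scatter), and this pair differs at that oxygen alone, with the configuration as drawn unchanged. The stereocentre at the saturated ring carbon gives no change at the digits printed from compound 2 to compound 4 (within the scatter), so at this one dose the drawn R and S forms of the hydroxy compound are not told apart: the fact that compounds 2 and 4 differ only in the configuration as drawn. Cyclopropyl in place of cyclohexyl on the amide-type nitrogen gives a number 43 percentage points higher from compound 1 to compound 4 (beyond the scatter), which shows that the amide-type nitrogen substituent also moves the reading strongly when the 2-hydroxycyclohexyl group is held fixed.

A single dose with both hydroxy compounds at the same reading leaves any difference in their potency hidden. As far as these compounds go, it also remains open how a methoxy group or an amine on that ring carbon would read, or a cyclopentyl group on the amide-type nitrogen.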